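Swapping an Arylamine for a Piperidine Ring

The source may report more compounds than this note shows. Statements on the series, on what has been measured and on what is new or still open speak of the compounds shown alone.

The shared core is seen in compound 1 `O=C1C=C(Nc2ccccc2F)C(=O)c2c1nc1n2[C@H]2OC[C@@H](O)[C@H]2OC1`. Going by the values given here, in a functional assay on ECa-109 cells for inhibition, with ECa-109 cell line (Homo sapiens) as the target, read by sulforhodamine B assay (on this read-out lower numbers stand for stronger inhibition and higher numbers for weaker inhibition), compound 1 gives 2760 nM, the only number reported here. Compound 2 `O=C1C(N2CCCC2)=CC(=O)c2c1nc1n2[C@H]2OC[C@@H](O)[C@H]2OC1` carries a pyrrolidin-1-yl group at the same place, and in this assay compound 2 reaches only the limit > 16000 nM, (the limit of > 16000 nM in this assay, at which 1 of the 2 values shown sits). Compound 3 `O=C1C=C(N2CCCCC2)C(=O)c2c1nc1n2[C@H]2OC[C@@H](O)[C@H]2OC1` has not yet been measured. (piperidin-1-yl in place of (2-fluorophenyl)amino on a double-bonded ring carbon). Compound 3, like compound 2, carries a ring amine where compound 1 has its arylamine. Compound 3 is therefore expected to be weaker in this assay than compound 1, with an expected step of a 5.4-fold higher number from compound 1 to compound 3 (0.74 log units; beyond the scatter) that goes beyond the usual scatter and may well end at the limit again. The estimate for compound 3 is 15000 nM, with a range from 5000 nM to 40000 nM.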

Compound 3, half-maximal inhibitory concentration: > 8000 nM
Compound 3 ended at the assay's limit; the forecaster's own chance of this, stated with the estimate: 55%; the middle value does not contradict the limit.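

Replacing (2-fluorophenyl)amino with piperidin-1-yl on this double-bonded ring carbon gives a readable loss of inhibition in this assay, with an at least 2.8-fold higher number from compound 1 to compound 3 (0.46 log units; beyond the scatter). Compound 3 reads only as a limit and not as a number, so this step gives a minimum size and not the full one: the limit of > 8000 nM in this assay, at which 1 of the 3 values shown sits.

The change takes away the aromatic ring and the hydrogen-bond donor together, so the loss cannot be assigned to either one alone.

The compounds shown leave open which of these two features matters for inhibition in this assay. A cyclohexylamino group, which keeps the amine hydrogen but has no aromatic ring, would help to separate them, as would a plain phenylamino group for the role of the fluorine.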